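A few compounds are considered here, and "the series" means these few. Any claim that something is new, unique, unknown or untested is made for them only; others in the source may bear on it.

Three analogues sharing one core have been examined in an ADME assay on MT4 cells (Homo sapiens) for cytotoxicity, read by MTT assay, with a stated time of 5 days; a lower number here means that less compound is tolerated, a higher number that more compound is tolerated. Compound 1 `Cc1cc(C)c(Oc2cc(Nc3ccc(C#N)cc3)ncc2C(=O)NCc2cn(Cc3ccccc3[N+](=O)[O-])nn2)c(C)c1` carries a 2-nitrophenyl group on a saturated chain carbon bound to an aromatic nitrogen, and in this assay compound 1 gives only a limit, > 212000 nM. Compound 2 `Cc1cc(C)c(Oc2cc(Nc3ccc(C#N)cc3)ncc2C(=O)NCc2cn(Cc3ccccc3F)nn2)c(C)c1` differs by fluoro in place of nitro on an aromatic carbon, and in this assay compound 2 likewise gives only a limit, > 222000 nM. Compound 3 `Cc1cc(C)c(Oc2cc(Nc3ccc(C#N)cc3)ncc2C(=O)NCc2cn(Cc3ccc(F)cc3)nn2)c(C)c1` bears 4-fluorophenyl in place of 2-fluorophenyl on that chain carbon, and in this assay compound 3 again gives only a limit, >= 153000 nM. Compound 3 thus stands among three values that are all limits (the limit of > 212000 nM in this assay, at which 1 of the 3 values shown sits, (the limit of > 222000 nM in this assay, at which 1 of the 3 values shown sits), (the limit of >= 153000 nM in this assay, at which 1 of the 3 values shown sits)), and the steps a step that the two limits leave unreadable from compound 1 to compound 2, a step that the two limits leave unreadable from compound 1 to compound 3 and a step that the two limits leave unreadable from compound 2 to compound 3 cannot be sized. Compound 4 `Cc1cc(C)c(Oc2cc(Nc3ccc(C#N)cc3)ncc2C(=O)NCc2cn(CCCO)nn2)c(C)c1` is the next member: 2-hydroxyethyl in place of 4-fluorophenyl on a saturated chain carbon bound to an aromatic nitrogen. For the measured compounds named here, since none of the measured steps has a readable size, neither direction nor magnitude can be drawn from them for this change in this assay. Compound 4 is therefore expected to behave like its three predecessors, with a step that the limit leaves unreadable from compound 3 to compound 4 that means no change beyond the scatter. The estimate for compound 4 in this assay is 200000 nM, ranging from 100000 nM to 400000 nM, and most likely it will again be reported only as a limit.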

Compound 4, half-maximal cytotoxic concentration: 25200 nM
Estimate against measurement, compound 4: 7.9-fold (0.90 log units) above; measured number below the stated range.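

In this assay, for the compounds shown here, the replacement at this place, on a saturated chain carbon bound to an aromatic nitrogen, gives the first steps whose size can be read: an at least 6.0-fold lower number from compound 3 to compound 4 (0.78 log units; beyond the scatter), an at least 8.8-fold lower number from compound 2 to compound 4 (0.94 log units; beyond the scatter) and an at least 8.4-fold lower number from compound 1 to compound 4 (0.92 log units; beyond the scatter). All three run in the same direction and lie beyond the scatter, which shows that the group at this place can change how much compound the cells tolerate, something the steps among compound 1, compound 2 and compound 3 could not show, as none of them can be read. Compound 3 gives only a limit, as do compound 1 and compound 2, so each of the three new sizes is a minimum, and compound 4 is the only one of the four with a plain number: the limit of >= 153000 nM in this assay, at which 1 of the 4 values shown sits.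

The change from 4-fluorobenzyl to 3-hydroxypropyl removes the aromatic ring and brings in the hydroxyl in a single step, so the compounds shown cannot say which of the two goes with the lower number. A plain propyl chain would separate the two, while a longer chain ending in hydroxyl, an amine or a carboxylic acid would test how far the result extends beyond this one group.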